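The source may hold more compounds than are shown below. What is called first, only, known or untested is meant among the compounds shown, and "the series" means these compounds.

Compound 1 `COc1nc2ccc(Br)cc2cc1C(c1ccccc1)n1cc(-c2ccc(Br)cc2)nn1`: in an ADME assay on SK-OV-3 cells (Homo sapiens) for cytotoxicity, read by sulforhodamine B assay, with a stated time of 48 h, tested at 10 uM (on this read-out higher numbers stand for more inhibition at the one concentration tested (going by the name of the read-out) and lower numbers for less inhibition), compound 1 gives 13.4%.
Compound 2 `CCCCc1cn(C(c2ccccc2)c2cc3cc(Br)ccc3nc2OC)nn1`: compound 2 gives 11.1%.
Compound 3 `CCCCCCCCc1cn(C(c2ccccc2)c2cc3cc(Br)ccc3nc2OC)nn1`: compound 3 gives 2.06%.

Compound 3 has the lowest of the three numbers: against compound 2 the gap is a number 9 percentage points lower from compound 2 to compound 3 (within the scatter), and against compound 1 it is a number 11.3 percentage points lower from compound 1 to compound 3 (beyond the scatter). Compound 4 `COc1nc2ccc(Br)cc2cc1C(c1ccccc1)n1cc(CCCO)nn1` differs from compound 3 by hydroxy in place of pentyl on a saturated chain carbon, three bonds along the chain from an aromatic carbon. Going by the values given here, the only measured step touching this chain is the one where the chain grew, a number 9 percentage points lower from compound 2 to compound 3 (within the scatter), and the step of a number 2.3 percentage points lower from compound 1 to compound 2 (within the scatter) also gave only a small shift. Cutting the chain back is expected to undo little more than that, so the step of a number 7.9 percentage points higher from compound 3 to compound 4 (within the scatter) is expected to be small and upward, toward the level of compound 2. Compound 4 is therefore estimated at 10%, between 0% and 22%.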

Compound 4, a percentage reported as inhibition, at one concentration (the size of the read-out at that concentration, not a potency): 13.8%
Compound 4: middle estimate off by 3.8 percentage points, on the low side; the measured number falls inside the stated range.
By their numbers in this assay, from the lowest: compounds 3, 2, 1 and 4 (each within the scatter of the next, the first and the last beyond it).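

In this assay, putting hydroxy in place of pentyl on this chain produces a step that can be read (a number 11.7 percentage points higher from compound 3 to compound 4 (beyond the scatter)), so the octyl chain of compound 3 stands apart from the 3-hydroxypropyl chain of compound 4. Against the butyl chain, hydroxy in place of methyl leaves the two numbers within the scatter (a number 2.7 percentage points higher from compound 2 to compound 4 (within the scatter)), and the same holds for 3-hydroxypropyl in place of 4-bromophenyl (a number 0.4 percentage points higher from compound 1 to compound 4 (within the scatter)). Nothing available explains these results. From the compounds shown here alone, it remains open whether an amine or a carboxylic acid at the chain end would read like hydroxy, and whether hydroxy on a longer chain would stay level with compound 4.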